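The source may report more compounds than this note shows. Statements on the series, on what has been measured and on what is new or still open speak of the compounds shown alone.

In a functional assay (brain) for displacement of a labelled ligand, with Rattus norvegicus as the target (on this read-out higher numbers stand for weaker inhibition and lower numbers for stronger inhibition), compound 2 `CN[C@@H](C)[C@H]1COC(c2ccccc2)(c2ccccc2)O1` gives 703 nM. Within the data shown here, only one other compound has been measured, compound 1 `NC[C@H]1COC(c2ccccc2)(c2ccccc2)O1`, which gives 1400 nM in this assay, and the step of a 2.0-fold lower number from compound 1 to compound 2 (0.30 log units; within the scatter) is of a size that repeated measurements alone could produce. Among the measured compounds shown here, compound 3 `c1ccc(C2(c3ccccc3)OC[C@H]([C@@H]3CCCN3)O2)cc1` has not yet been measured in this assay. pyrrolidin-2-yl in place of 1-(methylamino)ethyl on a saturated ring carbon The single measured step, which also changed the group on a saturated ring carbon, moved the number only within the scatter, so no step beyond the scatter is expected for this change either, with at most a slight lean towards a lower number. Compound 3 is therefore expected to show a 1.4-fold lower number from compound 2 to compound 3 (0.15 log units; within the scatter) in this assay, giving an estimate of 500 nM with a range from 150 nM to 2000 nM.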

Compound 3, inhibition constant: > 10000 nM
Compound 3: only a limit was reported; the forecaster's own chance of this, stated with the estimate: 3%; middle value at least 20-fold (1.30 log units) away from the limit.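

The position on a saturated ring carbon is less forgiving than the earlier step suggested: pyrrolidin-2-yl in place of 1-(methylamino)ethyl gives an at least 14-fold higher number from compound 2 to compound 3 (1.15 log units; beyond the scatter) in this assay, a large step. Pyrrolidin-2-yl in place of aminomethyl gives an at least 7.1-fold higher number from compound 1 to compound 3 (0.85 log units; beyond the scatter), so the group with a ring stands apart from both groups without one, and those two lie within the scatter of each other. The value for compound 3 is only a limit, so the full size of both steps stays unknown: the limit of > 10000 nM in this assay, at which 1 of the 3 values shown sits.

The compounds shown cannot tell whether any ring at this position goes with such a high number, or only this ring with this stereocentre. A piperidin-2-yl group, or pyrrolidin-2-yl with the opposite stereocentre, would bear on that question.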